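Removing the phenyl from the core of compound 1

A few compounds are considered here, and "the series" means these few. Any claim that something is new, unique, unknown or untested is made for them only; others in the source may bear on it.

Measured so far:
compound 1 `O=C(NCCCCCCn1c(-c2ccccc2)cc2ccccc21)Oc1ccccc1`: 520 nM
compound 2 `O=C(NCCCCCCn1c(-c2ccccc2)c(-c2ccccc2)c2ccccc21)Oc1ccccc1`: 4700 nM
compound 3 `O=C(NCCCCCCn1ccc2ccccc21)Oc1ccccc1`: not yet measured

Of the compounds shown here, two have been measured in an assay on microsomes from brain (strain Sprague-Dawley) for inhibition of Fatty-acid amide hydrolase 1 (Rattus norvegicus), read by fluorescence and HPLC, with stated times of 10 min and 60 min; a higher number here means a weaker inhibitor, a lower number a stronger inhibitor. Compound 1 gives 520 nM, the lowest of the two numbers; its nearest neighbour is compound 2, which in this assay gives 4700 nM. Among the measured compounds shown here, the only measured step is a 9.0-fold higher number from compound 1 to compound 2 (0.96 log units; beyond the scatter), a phenyl entering on an aromatic carbon of the shared core. Compound 3 differs from compound 1 by hydrogen in place of phenyl on an aromatic carbon. For the measured compounds named here, no measured step removes a phenyl from this core; the step from compound 1 to compound 2 concerns a phenyl that enters rather than one that leaves, and so bears only loosely on the change at hand. It shows that a further phenyl on the core raised the number, but whether taking the existing phenyl away raises or lowers the number cannot be read from two values. The analyst therefore expects a modest shift in this assay, most likely upward, with wide uncertainty, and takes a 2.3-fold higher number from compound 1 to compound 3 (0.36 log units; beyond the scatter) as the expected step. The estimate for compound 3 is 1200 nM, within 300 nM to 5000 nM.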

Compound 3, half-maximal inhibitory concentration: 250 nM
Estimate against measurement, compound 3: 4.8-fold (0.68 log units) above; measured number outside the range, below it.
By their numbers in this assay, from the lowest: compound 3; then compound 1; then compound 2.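

In this assay, hydrogen in place of the phenyl on this aromatic carbon, next to the ring nitrogen, brings a 2.1-fold lower number from compound 1 to compound 3 (0.32 log units; beyond the scatter), so the phenyl at this position is not required for inhibition at the level seen with compound 1. Read with a 9.0-fold higher number from compound 1 to compound 2 (0.96 log units; beyond the scatter), the result means that both single changes on the shared core point the same way: within each pair, the compound with the additional phenyl has the higher number, and no compound shown goes against this, although only these two steps support it. The measurements offer no information on why the number falls when this phenyl leaves.

The compounds shown leave open whether a group smaller than phenyl, such as methyl, or a different one, such as an amine or a methoxy group, on this aromatic carbon would lower the number further or raise it again. They also leave open whether the same step would hold with a shorter or longer chain on the ring nitrogen.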